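Lengthening the Chain Between Core and Chlorophenoxy Group

This account rests on a few compounds, and the source may have more. Where it says the series, first, only, none or still open, it means among the compounds named here.

Three compounds with a shared core have been compared in a functional assay on DLD-1 cells (Homo sapiens) for cytotoxicity; on this read-out lower numbers stand for stronger inhibition and higher numbers for weaker inhibition. Compound 1, `CC1C(=O)N(CCCCCCOc2ccc(Cl)cc2)/C(=N\C#N)N1c1ccncc1`, gives 333 nM in this assay. Going by the values given here, compound 2, `CCC1C(=O)N(CCCCCCOc2ccc(Cl)cc2)/C(=N\C#N)N1c1ccncc1`, gives 3560 nM, and the step of an 11-fold higher number from compound 1 to compound 2 (1.03 log units; beyond the scatter) is the only single-point change among the measured compounds. Compound 3, `N#C/N=C1\N(CCCCCOc2ccc(Cl)cc2)C(=O)C(c2ccccc2)N1c1ccncc1`, gives 337 nM, which is the second highest of the three numbers: it sits within the scatter of compound 1, while its distance to compound 2 lies beyond the scatter.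

Compound 4, `N#C/N=C1\N(CCCCCCOc2ccc(Cl)cc2)C(=O)C(c2ccccc2)N1c1ccncc1`, differs from compound 3 in one place: (4-chlorophenoxy)methyl in place of 4-chlorophenoxy on a saturated chain carbon, five bonds along the chain from an amide-type nitrogen in a ring. Among the compounds with values here, no measured step alters the chain in this way. Within the data shown here, the one measured step, an 11-fold higher number from compound 1 to compound 2 (1.03 log units; beyond the scatter), concerns a substituent on the saturated ring carbon and says nothing about chain length. Compounds 1 and 3 carry chains of different length but also differ on the ring carbon, and their two values fall within the scatter of each other. Among the measured compounds shown here, with no step that bears directly on the change, the step of a 1.0-fold higher number from compound 3 to compound 4 (0.00 log units; within the scatter) is expected to stay within the scatter. Compound 4 is therefore estimated at 340 nM, with a range from 120 nM to 1000 nM.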

Compound 4, half-maximal inhibitory concentration: 37 nM
Compound 4: the middle estimate sits 9.2-fold (0.96 log units) above what was measured; the whole stated range lies above it.
By their numbers in this assay, from the lowest: compound 4; then compounds 1 and 3 (each within the scatter of the next); then compound 2.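

In this assay, going by these compounds alone, the step of a 9.1-fold lower number from compound 3 to compound 4 (0.96 log units; beyond the scatter) is the first measured change to the chain itself, and it shows that swapping 4-chlorophenoxy for (4-chlorophenoxy)methyl at this place moves the number beyond the scatter, so this position is sensitive to a change of a single heavy atom. With the chain held the same, the saturated ring carbon can now also be read for phenyl: the step of a 9.0-fold lower number from compound 1 to compound 4 (0.95 log units; beyond the scatter) replaces methyl and the step of a 96-fold lower number from compound 2 to compound 4 (1.98 log units; beyond the scatter) replaces ethyl, which leaves compound 4 as the most potent of the compounds shown, with both steps beyond the scatter. Nothing given here explains either the chain step or the ring-carbon steps.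

On these data alone, whether a longer chain, such as 2-(4-chlorophenoxy)ethyl or 3-(4-chlorophenoxy)propyl at this same place, would lower the number again or raise it stays open, as does whether the chain step would have the same size with methyl or ethyl on the saturated ring carbon instead of phenyl. Equally open, as far as these compounds go, is how an amine or a carboxylic acid at the end of the chain, in place of 4-chlorophenoxy, would read out.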